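A few compounds are considered here, and "the series" means these few. Any claim that something is new, unique, unknown or untested is made for them only; others in the source may bear on it.

Measured compounds: compound 1 `CC(C)n1ncc2c(C(=O)NCc3cn(-c4cccc(F)c4)nn3)cccc21`, compound 2 `CC(C)n1ncc2c(C(=O)NCc3cn(-c4ccc(C(F)(F)F)cc4)nn3)cccc21`.

In a functional assay on PC-3 cells (Homo sapiens) for inhibition, read by MTT assay, with a stated time of 72 h (on this read-out higher numbers stand for weaker inhibition and lower numbers for stronger inhibition), compound 1 gives 36100 nM. In this assay, for the measured compounds named here, compound 2 gives 38600 nM; this is the higher of the two numbers, but the only step, a 1.1-fold higher number from compound 1 to compound 2 (0.03 log units; within the scatter), lies within the scatter, so the two compounds are not separable here.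

Compound 3 `CCc1ccc(-n2cc(CNC(=O)c3cccc4c3cnn4C(C)C)nn2)cc1` differs from compound 2 by ethyl in place of trifluoromethyl on an aromatic carbon. Going by the values given here, the one measured step also swapped the group on this phenyl ring and moved nothing beyond the scatter, so no step beyond the scatter is expected from compound 2 to compound 3, that is a 1.1-fold lower number from compound 2 to compound 3 (0.04 log units; within the scatter). In this assay compound 3 is expected to give 35000 nM, within 15000 nM to 80000 nM.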

Compound 3, half-maximal inhibitory concentration: 26600 nM
The estimate for compound 3 lay 1.3-fold (0.12 log units) above the measured number, within the range that was stated.
By their numbers in this assay, from the lowest: compounds 3, 1 and 2 (each within the scatter of the next).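

In this assay, ethyl in place of trifluoromethyl on this phenyl ring gives a 1.5-fold lower number from compound 2 to compound 3 (0.16 log units; within the scatter), so a substituent with no fluorine stays within the scatter of the trifluoromethyl compound. The step of 4-ethylphenyl in place of 3-fluorophenyl gives a 1.4-fold lower number from compound 1 to compound 3 (0.13 log units; within the scatter), and the three compounds remain inseparable at this position. Nothing at hand bears on a reason for these numbers.

Going by these compounds, whether an amine, a carboxylic acid or a longer chain on this phenyl ring would move the number beyond the scatter stays open. On these data alone, the effect of any change on the shared core also stays open.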